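The source may report more compounds than this note shows. Statements on the series, on what has been measured and on what is new or still open speak of the compounds shown alone.

Measured so far in a functional assay on MDA-MB-231 cells (Homo sapiens) for antiproliferative activity, read by MTT assay, with stated times of 72 h and 4 h; on this read-out lower numbers stand for stronger inhibition and higher numbers for weaker inhibition:
- compound 1 `Cc1nc(C(=O)Nc2ccc(Cl)c(-c3nnc4c(Cl)cccn34)c2)cs1`: a limit, > 100000 nM
- compound 2 `O=C(Nc1ccc(Cl)c(-c2nnc3c(Cl)cccn23)c1)c1cccnc1`: a limit, > 100000 nM
- compound 3 `O=C(Nc1ccc(Cl)c(-c2nnc3c(Cl)cccn23)c1)c1ccc(Cl)cc1`: a limit, > 100000 nM

Compound 3 stands at the limit of this assay, as shown by the limit of > 100000 nM in this assay, at which 3 of the 3 values shown sit. The steps a step that the two limits leave unreadable from compound 1 to compound 3 and a step that the two limits leave unreadable from compound 2 to compound 3 are therefore unreadable, and so is a step that the two limits leave unreadable from compound 1 to compound 2.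

Compound 4 `O=C(Nc1ccc(Cl)c(-c2nnc3c(Cl)cccn23)c1)c1cccc(Cl)c1` differs from compound 3 only in this: 3-chlorophenyl in place of 4-chlorophenyl on a carbonyl carbon. For the measured compounds named here, no measured step swaps 4-chlorophenyl for 3-chlorophenyl; the only steps at the carbonyl carbon are the three unreadable ones. With every value at the limit, compound 4 is expected to stay there too, giving an estimated step of a number no higher from compound 3 to compound 4 (the limit leaves the size open). Compound 4 is estimated at 100000 nM, range 30000 nM to 300000 nM, most likely reported as a limit.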

Compound 4, half-maximal inhibitory concentration: 66100 nM
Estimate against measurement, compound 4: 1.5-fold (0.18 log units) above; measured number inside the range.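

In this assay, for the compounds shown here, 3-chlorophenyl on the carbonyl carbon gives the first number that is not a limit, so this position is no longer wholly unreadable. The readings are an at least 1.5-fold lower number from compound 3 to compound 4 (0.17 log units; that floor lies within the scatter) together with an at least 1.5-fold lower number from compound 2 to compound 4 (0.17 log units; that floor lies within the scatter) and an at least 1.5-fold lower number from compound 1 to compound 4 (0.17 log units; that floor lies within the scatter) in this series. Going by these compounds, the steps among compound 1, compound 2 and compound 3 still cannot be read, and the true size of each step to compound 4 stays open. Also open, on these data alone, is what an amine or a carboxylic acid on the phenyl ring would do to the number.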